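Notes on the aryl group carried by the ring nitrogen

A few compounds are considered here, and "the series" means these few. Any claim that something is new, unique, unknown or untested is made for them only; others in the source may bear on it.

Two members of this series have been measured in a functional assay on the whole organism (strain Swiss albino) for inhibition, with Mus musculus as the target, in the writhing test, with a stated time of 30 min, at a dose of 10 mg/kg by the oral route; on this read-out lower numbers stand for a weaker effect and higher numbers for a stronger effect at the one dose given. Compound 1, `Cc1c(/C=N\O)cc(-c2ccc(S(C)(=O)=O)cc2)n1-c1cccc(F)c1`, gives 32% in this assay. Compound 2, `Cc1c(/C=N\O)cc(-c2ccc(S(C)(=O)=O)cc2)n1-c1ccc(F)c(F)c1`, gives 19% in this assay. Within the data shown here, the single measured step, a number 13 percentage points lower from compound 1 to compound 2 (beyond the scatter), is the only comparison available, and on it compound 2 stands lowest of the two numbers, with compound 1 the nearest value and beyond the scatter above it.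

Compound 3, `Cc1c(/C=N\O)cc(-c2ccc(S(C)(=O)=O)cc2)n1-c1ccccc1`, has not yet been measured. The change from compound 2 is phenyl in place of 3,4-difluorophenyl on an aromatic nitrogen. Among the measured compounds shown here, this step runs against the direction of the one known step: where adding fluoro in place of hydrogen lowered the read-out from compound 1 to compound 2, compound 3 removes both fluorines from that aryl group. Only a number 13 percentage points lower from compound 1 to compound 2 (beyond the scatter) bears on it, and it argues for a rise of comparable size. No measurement of the phenyl compound exists, so the second fluorine removal is unanchored. The expected step in this assay is a number 15 percentage points higher from compound 2 to compound 3 (beyond the scatter). Compound 3 is thus estimated at 34%, with a range from 20% to 48%.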

Compound 3, a percentage reported as inhibition, in the whole organism at one dose (the size of the read-out at that dose, not a potency): 27%
Beside the measured number, compound 3's estimate is 7 percentage points above it; the range from low to high includes it.
By their numbers in this assay, from the lowest: compounds 2, 3 and 1 (each within the scatter of the next, the first and the last beyond it).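

In this assay the phenyl group on the aromatic nitrogen does not separate from either fluorinated aryl group, with a number 8 percentage points higher from compound 2 to compound 3 (within the scatter) and a number 5 percentage points lower from compound 1 to compound 3 (within the scatter) as the two new readings. Of the three steps among these compounds, only a number 13 percentage points lower from compound 1 to compound 2 (beyond the scatter) lies beyond the scatter, so the count of fluorines on this aryl group does not set a graded order, and compound 3 gives no sign that removing both fluorines from the group of compound 2 changes the read-out. Among these compounds, no measurement at hand accounts for the one step beyond the scatter or for the closeness of compound 3 to the other two.

The compounds shown leave open whether a group other than fluoro on this aryl ring, such as methoxy, an amine or a carboxylic acid, would move the read-out beyond the scatter, and whether a saturated ring such as cyclohexyl could stand in place of the aryl group on the nitrogen. They also leave open whether the small gaps among these three compounds would persist at other doses, since each read-out comes from one dose and is no measure of potency.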